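Replacing 4,4-dimethylpiperidin-1-yl with 4-(tert-butyl)piperidin-1-yl

A few compounds are considered here, and "the series" means these few. Any claim that something is new, unique, unknown or untested is made for them only; others in the source may bear on it.

In a functional assay on MEF cells (Mus musculus) for antiproliferative activity, read by luminescence, with a stated time of 16 h (a lower number here means that less compound is needed, a higher number that more compound is needed for the effect), compound 1 (`O=C(Nc1ccc(S(=O)(=O)N2CCC(F)CC2)cc1)c1ccc([N+](=O)[O-])o1`) gives > 20000 nM as its reading, which is a limit of the assay and not a number. For the measured compounds named here, compound 2 (`CC1(C)CCN(S(=O)(=O)c2ccc(NC(=O)c3ccc([N+](=O)[O-])o3)cc2)CC1`) gives 9200 nM in the same test, the only exact number so far. Going by the values given here, the one measured step is an at least 2.1-fold lower number from compound 1 to compound 2 (0.33 log units; beyond the scatter) and comes with 4,4-dimethylpiperidin-1-yl in place of 4-fluoropiperidin-1-yl on a sulfonyl sulfur. Compound 3 (`CC(C)(C)C1CCN(S(=O)(=O)c2ccc(NC(=O)c3ccc([N+](=O)[O-])o3)cc2)CC1`) changes that same place, with 4-(tert-butyl)piperidin-1-yl in place of 4,4-dimethylpiperidin-1-yl (4-(tert-butyl)piperidin-1-yl in place of 4,4-dimethylpiperidin-1-yl on a sulfonyl sulfur) on a sulfonyl sulfur. Among the compounds with values here, a single step that starts at a limit is thin evidence, yet an at least 2.1-fold lower number from compound 1 to compound 2 (0.33 log units; beyond the scatter) is the only guide, so a modest further drop is expected in this assay for compound 3. The expected move is a 2.0-fold lower number from compound 2 to compound 3 (0.31 log units; beyond the scatter) on this estimate. For compound 3 the estimated value is 4500 nM within an expected range of 1300 nM to 15000 nM in this test.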

Compound 3, half-maximal effective concentration: 2100 nM
Estimate against measurement, compound 3: 2.1-fold (0.33 log units) above; measured number inside the range.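

In this assay, for the compounds shown here, the move to 4-(tert-butyl)piperidin-1-yl on the sulfonyl sulfur brings a 4.4-fold lower number from compound 2 to compound 3 (0.64 log units; beyond the scatter), and this is the first step at this place measured between two exact numbers, so its size can be stated and not merely bounded. Across the three compounds, the number falls from the 4-fluoropiperidin-1-yl through the 4,4-dimethylpiperidin-1-yl to the 4-(tert-butyl)piperidin-1-yl group, with none going against that order, and tert-butyl in place of fluoro on a saturated ring carbon gives an at least 9.5-fold lower number from compound 1 to compound 3 (0.97 log units; beyond the scatter). The true size of that last step stays unknown because compound 1 reads as a limit and not as a number: the limit of > 20000 nM in this assay, at which 1 of the 3 values shown sits.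

The three compounds cannot tell whether the number tracks the heavy-atom count of the group or the particular shape of tert-butyl, since a straight butyl chain at the same ring carbon is not among them. From the compounds shown here alone, it also remains open whether the fall would continue with a phenyl ring at that carbon, or would survive an amine or a carboxylic acid there.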